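Tert-butyl ester to primary amide: cytotoxicity outlook

The source may report more compounds than this note shows. Statements on the series, on what has been measured and on what is new or still open speak of the compounds shown alone.

Compound 2 `CC(C)(C)OC(=O)c1ccc(CN2C(=O)c3ccccc3S2(=O)=O)cc1` reaches in an ADME assay on RAW264.7 cells (Mus musculus) for cytotoxicity, read by WST assay (on this read-out lower numbers stand for higher toxicity in this test and higher numbers for lower toxicity in this test), only a limit of the test, > 100000 nM. Compound 1 `O=C(c1ccc(CN2C(=O)c3ccccc3S2(=O)=O)cc1)N1CCCCC1` gives 69200 nM in this assay, so the step of an at least 1.4-fold higher number from compound 1 to compound 2 (0.15 log units; that floor lies within the scatter) sits within the scatter and rests on (the limit of > 100000 nM in this assay, at which 1 of the 2 values shown sits). Compound 3 `NC(=O)c1ccc(CN2C(=O)c3ccccc3S2(=O)=O)cc1` has not yet been measured; it differs from compound 2 by amino in place of tert-butoxy on a carbonyl carbon. Among the compounds with values here, the only measured step at this carbonyl carbon, from compound 1 to compound 2, was small. For compound 3 no step beyond the scatter is expected in this assay, estimated as a number no higher from compound 2 to compound 3 (the limit leaves the size open). Compound 3 is expected to give 100000 nM (range 50000 nM to 200000 nM).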

Compound 3, concentration lethal to 50% of the cells: > 100000 nM
Compound 3: a limit, no number; the forecaster's own chance of this, stated with the estimate: 60%; the middle value sits exactly at the limit.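

Working notes: a second small change at this carbonyl carbon, amino in compound 3, also ends at a limit of this assay, as tert-butoxy does in compound 2: the limit of > 100000 nM in this assay, at which 2 of the 3 values shown sit.

Against the piperidin-1-yl amide, the record reads an at least 1.4-fold higher number from compound 1 to compound 3 (0.15 log units; that floor lies within the scatter), so no change beyond the scatter is established. The step between compound 2 and compound 3 cannot be read, as both values are limits.

On these data alone, whether the carboxylic acid, with hydroxy on this carbonyl carbon, or dimethylamino there would give a readable number in this assay stays open.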